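Sulfonamide series: fluoro for methyl on the sulfonyl arene

A few compounds are considered here, and "the series" means these few. Any claim that something is new, unique, unknown or untested is made for them only; others in the source may bear on it.

Measured compounds:
compound 1, `NS(=O)(=O)c1ccc(NC(=O)c2ccc(F)cc2)cc1`: 5910 nM
compound 2, `Cc1ccc(S(=O)(=O)Nc2ccc(S(N)(=O)=O)cc2)cc1`: 14500 nM
compound 3, `Cc1ccc(S(=O)(=O)NCc2ccc(S(N)(=O)=O)cc2)cc1`: 140 nM

All three were tested in an assay on isolated protein for inhibition of Intestinal-type alkaline phosphatase (Bos taurus), read by chemiluminescence and spectrophotometry; on this read-out lower numbers stand for stronger inhibition and higher numbers for weaker inhibition. Compound 2 gives the highest number of the three. The nearest is compound 1, whose number is lower, a gap beyond the usual scatter; compound 3 lies much further away, with a number far lower than that of compound 2, again beyond the scatter. No pair of these compounds differs in a single place, so no step between measured compounds can be read off.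

Compound 4, `NS(=O)(=O)c1ccc(NS(=O)(=O)c2ccc(F)cc2)cc1`, has not been measured in this assay . It differs from compound 2 in one place: fluoro in place of methyl on an aromatic carbon. The same replacement of a methyl by a fluoro on a six-membered aromatic ring appears nowhere among the measured pairs, so the size and direction of the step must be estimated without a direct precedent. The expectation is that the step of a 1.5-fold lower number from compound 2 to compound 4 (0.16 log units; within the scatter) is small, within or only slightly beyond the scatter, with the number for compound 4 staying in the weak range where compound 2 sits rather than approaching compound 3. Compound 4 is therefore estimated at 10000 nM, with a range from 3000 nM to 30000 nM.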

Compound 4, half-maximal inhibitory concentration: 1130 nM
Compound 4: middle estimate off by 8.8-fold (0.95 log units), on the high side, outside the stated range (below it).
By their numbers in this assay, from the lowest: compound 3; then compound 4; then compound 1; then compound 2.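

In this assay, the change from 4-methylphenyl to 4-fluorophenyl gives a 13-fold lower number from compound 2 to compound 4 (1.11 log units; beyond the scatter), so this aromatic carbon, para to a large group, is a sensitive place in the series. Among the compounds shown here, the exchange is as small as one can be: one heavy atom for one heavy atom, with no ring, hydrogen-bond donor, hydrogen-bond acceptor or net charge entering or leaving, yet the step is large and lies beyond the scatter, something the earlier compounds could not show as they offered no single-place step at all. Nothing at hand accounts for the size or direction of this step, which therefore stands as an observation only.

Going by these compounds, with only methyl and fluoro compared at this carbon, it remains open whether the trend is specific to fluoro or would extend to a chloro, a methoxy, a nitrile or a plain hydrogen in the same place. On these data alone, it is also open whether the same exchange would give a step of similar size on the core of compound 3, whose number already lies far lower.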